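Replacing the Hydroxamic Acid Head With a Carboxylic Acid Chain

A few compounds are considered here, and "the series" means these few. Any claim that something is new, unique, unknown or untested is made for them only; others in the source may bear on it.

Among the measured compounds shown here, compound 1 `O=C(NO)c1ccc(NCCOc2ccc3cc2COC/C=C/COCc2cccc(c2)-c2ccnc(n2)N3)cc1` is the stronger of the two compounds measured so far: in an assay on Sf9 cells for inhibition of protein deacetylase HDAC6 (Homo sapiens), read by fluorescence, with a stated time of 2 h (on this read-out higher numbers stand for weaker inhibition and lower numbers for stronger inhibition), compound 1 gives 395 nM. Compound 2 `O=C(O)CCCCCOc1ccc2cc1COC/C=C/COCc1cccc(c1)-c1ccnc(n1)N2` gives 45000 nM, and the step of a 110-fold higher number from compound 1 to compound 2 (2.06 log units; beyond the scatter) shows that swapping the head group costs a great deal. Compound 3 `O=C(O)CCCCCCCOc1ccc2cc1COC/C=C/COCc1cccc(c1)-c1ccnc(n1)N2` makes a closely related change, (5-carboxypentyl in place of (4-(hydroxycarbamoyl)phenyl)amino on a saturated chain carbon, two bonds along the chain from an oxygen on an aromatic ring). Here the entering group is 5-carboxypentyl rather than the 3-carboxypropyl of compound 2, so a loss of similar size is expected, a 100-fold higher number from compound 1 to compound 3 (2.01 log units; beyond the scatter). Compound 3 is therefore estimated at 40000 nM, within a range from 10000 nM to 150000 nM.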

Compound 3, half-maximal inhibitory concentration: 10000 nM
Compound 3: middle estimate off by 4.0-fold (0.60 log units), on the high side; low and high end bracket the measured number.
By their numbers in this assay, from the lowest: compound 1; then compound 3; then compound 2.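

Within the two carboxylic acids, chain length matters: 2-carboxyethyl in place of carboxy on the chain gives a 4.5-fold lower number from compound 2 to compound 3 (0.65 log units; beyond the scatter), so the longer chain wins back part of the loss. It does not win back all of it, since 5-carboxypentyl in place of (4-(hydroxycarbamoyl)phenyl)amino still leaves a 25-fold higher number from compound 1 to compound 3 (1.40 log units; beyond the scatter). Nothing available explains why the longer acid chain gives the lower number. On these data alone, whether a chain longer than 5-carboxypentyl would lower the number further stays open, as does what an amine at the chain end would give.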